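The compounds below may be only part of what the source reports. "The series", "measured", "known", "first", "only" and "open" are said of these compounds alone.

Notes on the stilbene-type series. In an assay on HepG2 cells for activation of nuclear factor erythroid 2-related factor 2 (Homo sapiens), read by a luciferase reporter, with a stated time of 5 h (on this read-out lower numbers stand for an effect already at smaller amounts and higher numbers for an effect only at larger amounts of compound), compound 1 `Cc1ccc(/C=C/c2ccc(F)cc2)cc1` gives 1300 nM. Compound 2 `Cc1ccc(/C=C/c2ccc(F)c(F)c2)cc1` gives 2600 nM in this assay. Between them stands a 2.0-fold higher number from compound 1 to compound 2 (0.30 log units; within the scatter), the change being (fluoro in place of hydrogen on an aromatic carbon). Compound 3 `Fc1ccccc1/C=C/c1ccccc1F` gives 4300 nM in this assay; its value and that of compound 2 lie within the scatter of each other, while against compound 1 its number is higher beyond the scatter. How the core of compound 3 differs from that of compound 1 is not broken down here. Compound 4 `Fc1ccccc1/C=C/c1c(F)cccc1F` is not yet measured and differs from compound 3 by fluoro in place of hydrogen on an aromatic carbon. This is the same kind of change as from compound 1 to compound 2, not the same one: there the entering fluoro sits ortho to a fluoro group and meta to a group of 9 heavy atoms, here ortho to a group of 9 heavy atoms and meta to a fluoro group. Beside the earlier step, an expected 1.7-fold higher number from compound 3 to compound 4 (0.24 log units; within the scatter) is assumed in this assay because the same kind of change gave a 2.0-fold higher number from compound 1 to compound 2 (0.30 log units; within the scatter). Compound 4 is therefore estimated at 7500 nM in this assay, between 3000 nM and 18000 nM.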

Compound 4, half-maximal effective concentration: 1400 nM
Compound 4: the middle estimate sits 5.4-fold (0.73 log units) above what was measured, and the stated range ends above it.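

On these two cores, fluoro in place of hydrogen on an aromatic carbon does not carry over as a fixed shift in this assay: on the core of compound 3 it gives a 3.1-fold lower number from compound 3 to compound 4 (0.49 log units; beyond the scatter). Set beside the earlier step, the two differ: the same change on two cores in this assay, a 2.0-fold higher number (0.30 log units; within the scatter) from compound 1 to compound 2 and a 3.1-fold lower number (0.49 log units; beyond the scatter) from compound 3 to compound 4, 6.1-fold (0.79 log units) apart, beyond the scatter of two such steps With a single pair per core, this does not show whether the difference goes with the core or with the place of the entering fluoro, which in compound 4 is ortho to a group of 9 heavy atoms and meta to a fluoro group.

Going by these compounds, whether fluoro in that same place gives a lower number on the core of compound 1 remains open. So does how this assay responds on either core to a group other than fluoro, such as an amine or a carboxylic acid.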